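A few compounds are considered here, and "the series" means these few. Any claim that something is new, unique, unknown or untested is made for them only; others in the source may bear on it.

Compound 1 `COc1cc2c(cc1OC)C(c1ccc(N)cc1)=NN=C(S)C2` and compound 3 `COc1cc2c(cc1OC)C(c1ccc(N)cc1)=NNC(=O)C2` carry the same amino-bearing aromatic ring on cores that are not alike; the difference between the two cores is not broken down here. In a functional assay on the whole organism with Mus musculus as the target (on this read-out higher numbers stand for an effect only at larger amounts of compound and lower numbers for an effect already at smaller amounts), compound 1 gives 6.3 umol/kg, while compound 3 gives 15 umol/kg. Compound 2 `COc1cc2c(cc1OC)C(c1ccc([N+](=O)[O-])cc1)=NN=C(S)C2` arises from compound 1 by a single change: nitro in place of amino on an aromatic carbon. In this assay compound 2 gives 93.4 umol/kg, and the step is a 15-fold higher number from compound 1 to compound 2 (1.17 log units; beyond the scatter). Compound 4 `COc1cc2c(cc1OC)C(c1ccc([N+](=O)[O-])cc1)=NNC(=O)C2` has not yet been measured; it arises from compound 3 by the same change: nitro in place of amino on an aromatic carbon. Among the measured compounds shown here, only one earlier example of this change exists, and it sits on a different core, so the expectation is held loosely. For compound 4 the expected step is a 13-fold higher number from compound 3 to compound 4 (1.12 log units; beyond the scatter) in this assay, because the earlier step of a 15-fold higher number from compound 1 to compound 2 (1.17 log units; beyond the scatter) was large and towards a higher number. For compound 4 the estimated value in this assay is 200 umol/kg, with the range expected to run from 60 umol/kg to 700 umol/kg.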

Compound 4, dose for half-maximal effect: > 120 umol/kg
Compound 4 was reported as a limit (the forecaster's own chance of this, stated with the estimate: 15%); the middle value is on the limit's open side.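

In this assay, nitro in place of amino on an aromatic carbon again gives a higher number on the second core, an at least 8.0-fold higher number from compound 3 to compound 4 (0.90 log units; beyond the scatter). Set beside the earlier step, the direction of the change carries over from one core to the other, but the two sizes cannot be compared, so it remains unknown whether the change counts for equally much on both cores: the same change on two cores in this assay, a 15-fold higher number (1.17 log units; beyond the scatter) from compound 1 to compound 2 and an at least 8.0-fold higher number (0.90 log units; beyond the scatter) from compound 3 to compound 4; the limit leaves it open whether they differ The value of compound 4 is a limit and not a number, so the full size of its step remains unknown, and two cores are too few to support a rule beyond these compounds: the limit of > 120 umol/kg in this assay, at which 1 of the 4 values shown sits.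

The compounds shown leave open how other groups in the same place on the aromatic ring would behave on either core, such as a methylamino group, an acetamido group, a carboxylic acid or a chlorine atom. They also leave open which part of the difference between the two cores accounts for the gap between the amino-bearing compounds.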